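The compounds below may be only part of what the source reports. "The series", "measured", "known", "first", "only" and "open" are said of these compounds alone.

Measured so far in an ADME assay on HEp-2 cells (Homo sapiens) for cytotoxicity; a higher number here means that more compound is tolerated, a lower number that less compound is tolerated:

- compound 1, `O=c1n(Cc2nc3ccccc3n2CCCC(F)(F)F)c2cnccc2n1C1CC1`: 55700 nM
- compound 2, `N#CCCCn1c(Cn2c(=O)n(C3CC3)c3ccncc32)nc2ccccc21`: > 151000 nM; 109000 nM (2 entries)

For the measured compounds named here, compound 1 gives the only plain number in this assay, 55700 nM. For compound 2 one of the entries is a limit of the assay, not a number; its entries read (the several entries of compound 2 in this assay, > 151000 nM; 109000 nM (2 entries)). Going by the values given here, what the two sets show is that the numbered entry of compound 2 sits higher than the number of compound 1, so more of compound 2 is tolerated, but no single step between them is worked out here.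

Compound 3, `O=c1n(Cc2nc3ccccc3n2CCCO)c2cnccc2n1C1CC1`, is not yet measured in this assay. It differs from compound 1 by hydroxy in place of trifluoromethyl on a saturated chain carbon, three bonds along the chain from an aromatic nitrogen. No measured step of this kind exists in the series, so the direction rests only on the two compounds shown. The expectation for compound 3 is a step up in this assay, from compound 1 to compound 3 of a 1.5-fold higher number from compound 1 to compound 3 (0.18 log units; within the scatter), toward more compound tolerated. Compound 3 is therefore estimated at 85000 nM, within 35000 nM to 180000 nM, with a fair chance that only a limit is reported.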

Compound 3, half-maximal cytotoxic concentration: 245000 nM
For compound 3 the middle estimate is 2.9-fold (0.46 log units) below the measured one; measured number above the stated range.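

In this assay, for the compounds shown here, hydroxy in place of trifluoromethyl on a saturated chain carbon, three bonds along the chain from an aromatic nitrogen, gives the first readable step at this position: a 4.4-fold higher number from compound 1 to compound 3 (0.64 log units; beyond the scatter). The position therefore responds to a change of group in this assay, and the change from 4,4,4-trifluorobutyl to 3-hydroxypropyl on the shared core moves the number by more than the usual scatter, though this rests on a single pair. Compound 2, which carries a nitrile in the chain, has one entry that is a limit of the assay and not a number, so its entries give no exact place beside the other compounds: the several entries of compound 2 in this assay, > 151000 nM; 109000 nM (2 entries)

Going by these compounds alone, with only this pair, the loss of trifluoromethyl and the arrival of hydroxy cannot be separated as the source of the step. Going by these compounds, it also remains open whether an amine, a carboxylic acid or a longer chain ending in hydroxy at this place would shift the number in this assay in the same direction, and by a similar amount.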